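The source may hold more compounds than are shown below. What is called first, only, known or untested is meant among the compounds shown, and "the series" means these compounds.

Measured in a functional assay on K562 cells (Homo sapiens) for antiproliferative activity, read by MTT assay, with a stated time of 48 h; on this read-out lower numbers stand for stronger inhibition and higher numbers for weaker inhibition:
Compound 1 `Cn1cc(C2=C(c3nn(CCCN4CCCCC4)c4ncccc34)C(=O)N(c3cccc4ccccc34)C2=O)c2ccccc21`: 3180 nM
Compound 2 `Cn1cc(C2=C(c3n[nH]c4ncccc34)C(=O)NC2=O)c2ccccc21`: > 100000 nM

Only a limit is known for compound 2, at > 100000 nM, so this value is not a number and marks the weak end of the two results. Compound 3 `Cn1cc(C2=C(c3n[nH]c4ncccc34)C(=O)N(c3cccc4ccccc34)C2=O)c2ccccc21` is compound 2 with a single change: naphthalen-1-yl in place of hydrogen on an amide-type nitrogen in a ring. For the measured compounds named here, no measured pair isolates this change, so its size cannot be read directly from the data. The nearest guide is compound 1, which also carries naphthalen-1-yl on that nitrogen, together with a further side chain on the shared core, and compound 1 gives 3180 nM. On that basis, a real shift towards stronger inhibition is expected in this assay, though compound 3 is not expected to go beyond compound 1 and could stay at the limit. The expected change is an at least 5.0-fold lower number from compound 2 to compound 3 (0.69 log units; beyond the scatter). For compound 3 the estimated value is 20000 nM, with an expected range of 5000 nM to 100000 nM.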

Compound 3, half-maximal inhibitory concentration: > 100000 nM
Compound 3: only a limit was reported (the forecaster's own chance of this, stated with the estimate: 25%); at least 5.0-fold (0.69 log units) between middle value and limit.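

In this assay, compound 3 gives > 100000 nM, which is a limit and not a number, so naphthalen-1-yl on the amide-type nitrogen does not by itself produce a measurable value. The step from compound 2 to compound 3 cannot be read, because both compounds sit at the same limit: the limit of > 100000 nM in this assay, at which 2 of the 3 values shown sit. The other step can be read: putting hydrogen in place of 3-(piperidin-1-yl)propyl on the aromatic nitrogen gives an at least 31-fold higher number from compound 1 to compound 3 (1.49 log units; beyond the scatter), so with naphthalen-1-yl present, the measurable inhibition goes with that side chain.

On these data alone, it remains open whether 3-(piperidin-1-yl)propyl on the aromatic nitrogen would give a measurable value with hydrogen on the amide-type nitrogen, and so whether naphthalen-1-yl contributes anything at all. As far as these compounds go, it is also open whether the piperidine ring of the side chain could give way to a morpholine or a dimethylamino group, or whether the propyl link could give way to a longer chain, with the inhibition kept.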